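Bis-guanidine series: aminothiazole to imidazole swap, intrinsic activity

The source may report more compounds than this note shows. Statements on the series, on what has been measured and on what is new or still open speak of the compounds shown alone.

Measured compounds:
Compound 1 `Cc1nc(N)sc1CCCN/C(N)=N/C(=O)CCCCCCCCC(=O)/N=C(\N)NCCCc1sc(N)nc1C` gives 0.79 in an in vitro functional assay on Sf9 cells for agonist activity at histamine H2 receptor (Cavia porcellus); on this read-out lower numbers stand for smaller maximal responses and higher numbers for larger maximal responses.
Compound 2 `N/C(=N\C(=O)CCCCCCCCC(=O)/N=C(\N)NCCCc1c[nH]cn1)NCCCc1c[nH]cn1` gives 0.98 in this assay.
Compound 3 `Cc1nc(N)sc1CCCN/C(N)=N/C(=O)CCCCCCCCC(=O)/N=C(\N)NCCCc1cnc(N)s1` gives 0.89 in this assay.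

Compound 3 stands second highest of the three numbers; the nearest is compound 2, and the furthest is compound 1, both gaps being within the scatter. Within the data shown here, the only one-place step measured so far is a number 0.10 higher from compound 1 to compound 3 (within the scatter), which is within the scatter.

Compound 4 `Cc1nc(N)sc1CCCN/C(N)=N/C(=O)CCCCCCCCC(=O)/N=C(\N)NCCCc1c[nH]cn1` is not yet measured in this assay. It differs from compound 3 in one place: 1H-imidazol-4-yl in place of 2-amino-1,3-thiazol-5-yl on a saturated chain carbon, three bonds along the chain from an amine nitrogen. Among the measured compounds shown here, no measured step follows this exact change; the closest reading is the gap between compound 3 and compound 2, where the other arm also carries the imidazole, and that gap is within the scatter. The step a number 0.10 higher from compound 1 to compound 3 (within the scatter) on the other arm was likewise within the scatter. The expected step is therefore a number 0.010 higher from compound 3 to compound 4 (within the scatter), which is expected to be none beyond the scatter. Compound 4 is estimated at 0.9, with a range from 0.78 to 1.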

Compound 4, intrinsic activity: the largest response reached, as a fraction of the reference agonist's: 1.01
The estimate for compound 4 lay 0.11 below the measured number; measured number above the stated range.
By their numbers in this assay, from the lowest: compounds 1, 3, 2 and 4 (each within the scatter of the next, the first and the last beyond it).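

In this assay, 1H-imidazol-4-yl in place of 2-amino-1,3-thiazol-5-yl gives a number 0.12 higher from compound 3 to compound 4 (beyond the scatter), so a single change at this position on a saturated chain carbon now moves the read-out beyond the scatter. Replacing the 2-amino-4-methyl-1,3-thiazol-5-yl arm with 1H-imidazol-4-yl gives a number 0.22 higher from compound 1 to compound 4 (beyond the scatter), so the change raises the maximal response from either aminothiazole arm in these two pairs. With one imidazole arm held fixed, changing the other to 2-amino-4-methyl-1,3-thiazol-5-yl gives a number 0.030 higher from compound 2 to compound 4 (within the scatter), so that arm's identity is not resolved here. Nothing available explains these steps.

As far as these compounds go, whether 1H-imidazol-4-yl paired with 2-amino-1,3-thiazol-5-yl behaves like compound 4 remains open. Also open, from the compounds shown here alone, is whether the steps persist with a shorter chain linking the arms, or with a 1,2,4-triazole in place of the imidazole.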